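This account rests on a few compounds, and the source may have more. Where it says the series, first, only, none or still open, it means among the compounds named here.

Going by the values given here, in a functional assay on cells (Mast cell, Rattus norvegicus, strain Wistar) for activation, read by fluorescence, with a stated time of 15 min (a higher number here means that more compound is needed for the effect, a lower number that less compound is needed), compound 3 `CCCCCCCCCCCCCCCCCC(=O)OC[C@@H](O)COP(=O)(O)O[C@@H](C)[C@H](N)C(=O)O` gives 2000 nM, the lowest number of the three compounds measured so far. Compound 1 `CCCCCCCCCCCCCCCCCC(=O)CCCCOP(=O)(O)OC[C@H](N)C(=O)O` gives 5000 nM, and compound 2 `CCCCCCCCCCCCCCCCCC(=O)N(C)C[C@@H](O)COP(=O)(O)OC[C@H](N)C(=O)O` gives 10000 nM. Both gaps to compound 3 lie beyond the usual scatter, so compound 3 needs the least compound of this small set to produce the effect.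

Compound 4 `CCCCCCCCCCCCCCCCCC(=O)OC[C@@H](O)COP(=O)(O)OC[C@H](NC)C(=O)O` has the same atoms as compound 3, joined differently: a group of 7 heavy atoms (4 carbon, 1 nitrogen, 2 oxygen; no ring) in place of a group of 7 heavy atoms (4 carbon, 1 nitrogen, 2 oxygen; no ring), on an oxygen. The change sits on an oxygen whose other neighbours are phosphorus, and the entering group has 1 defined stereocentre where the leaving group has 2.

Among the compounds with values here, no measured pair isolates this kind of change, so the expectation rests only on the spread of the three values. With compound 3 at 2000 nM, the lowest of them, a higher number seems more likely than a lower one. The expected change is a 3.0-fold higher number from compound 3 to compound 4 (0.48 log units; beyond the scatter), an estimate that leaves much uncertainty. For compound 4 the estimated value is 6000 nM, with an expected range from 1800 nM to 20000 nM.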

Compound 4, half-maximal effective concentration: > 10000 nM
Compound 4: no number, only a limit; the forecaster's own chance of this, stated with the estimate: 20%; middle value at least 1.6-fold (0.22 log units) away from the limit.
By their numbers in this assay, from the lowest: compound 3; then compounds 1 and 2 (each within the scatter of the next).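

Going by these compounds alone, this is the first pair in the set that differs in one place, and the rearrangement on an oxygen whose other neighbours are phosphorus gives an at least 5.0-fold higher number from compound 3 to compound 4 (0.69 log units; beyond the scatter). The two groups match in heavy atoms, double bonds, hydrogen-bond donors and hydrogen-bond acceptors and differ in the count of defined stereocentres, so the arrangement at this position matters in this assay even when these counts barely change. In this assay compound 4 gives only a limit, > 10000 nM, and not a number: the limit of > 10000 nM in this assay, at which 1 of the 4 values shown sits.

The compounds shown leave open how this position would read with an ethyl group on the nitrogen, or with a carboxamide in place of the carboxylic acid. They also leave open whether the same change would have a similar effect on the cores of compound 1 and compound 2.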